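Amide substituent change on the chalcone series

A few compounds are considered here, and "the series" means these few. Any claim that something is new, unique, unknown or untested is made for them only; others in the source may bear on it.

Compound 3 `COc1cc(/C=C/C(=O)c2cccc(NC(=O)c3cccs3)c2)ccc1O` gives 0.38 ug/mL in a functional assay on HUVEC cells (Homo sapiens) for inhibition (on this read-out lower numbers stand for stronger inhibition and higher numbers for weaker inhibition), and holds the lowest number of the three measured compounds. The nearest is compound 2 `COC(=O)C(=O)Nc1cccc(C(=O)/C=C/c2ccc(O)c(OC)c2)c1`, which gives 1.5 ug/mL in this assay; the furthest is compound 1 `COc1cc(/C=C/C(=O)c2cccc(N)c2)ccc1O`, which gives 2.87 ug/mL in this assay. The steps of a 7.6-fold lower number from compound 1 to compound 3 (0.88 log units; beyond the scatter) and a 3.9-fold lower number from compound 2 to compound 3 (0.60 log units; beyond the scatter) both lie beyond the scatter, while a 1.9-fold lower number from compound 1 to compound 2 (0.28 log units; within the scatter) lies within it.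

Compound 4 `CCCC(=O)Nc1cccc(C(=O)/C=C/c2ccc(O)c(OC)c2)c1` differs from compound 3 in one place: propyl in place of thiophen-2-yl on a carbonyl carbon. Of the measured steps, a 3.9-fold lower number from compound 2 to compound 3 (0.60 log units; beyond the scatter) exchanges the group on the same carbonyl carbon, and a 7.6-fold lower number from compound 1 to compound 3 (0.88 log units; beyond the scatter) sets the (thiophen-2-yl)carbonyl against hydrogen on the nitrogen. Both show the (thiophen-2-yl)carbonyl with the lowest number and the other groups on the nitrogen higher. Removing the thiophen-2-yl for propyl is therefore expected to raise the number by a modest step, a 2.6-fold higher number from compound 3 to compound 4 (0.42 log units; beyond the scatter), with the exact size uncertain. Compound 4 is estimated at 1 ug/mL, within 0.4 ug/mL to 2.5 ug/mL.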

Compound 4, half-maximal inhibitory concentration: 1.27 ug/mL
Compound 4: the middle estimate sits 1.3-fold (0.10 log units) below what was measured, and the stated range covers the measured number.
By their numbers in this assay, from the lowest: compound 3; then compounds 4, 2 and 1 (each within the scatter of the next, the first and the last beyond it).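

In this assay the thiophen-2-yl on the carbonyl carbon also holds its lead over an open chain, with a 3.3-fold higher number from compound 3 to compound 4 (0.52 log units; beyond the scatter) beyond the scatter, so the lead of compound 3 is not tied to the comparison with methoxycarbonyl alone. Propyl and methoxycarbonyl cannot be told apart at this place, since a 1.2-fold lower number from compound 2 to compound 4 (0.07 log units; within the scatter) lies within the scatter. Against hydrogen on the nitrogen, propylcarbonyl gives a modest gain, a 2.3-fold lower number from compound 1 to compound 4 (0.35 log units; beyond the scatter) beyond the scatter, and this is smaller than the step the (thiophen-2-yl)carbonyl gives from the same compound.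

Going by these compounds, whether the lead of compound 3 belongs to the sulfur or to any five-membered aromatic ring stays open, as does the outcome with furan-2-yl, phenyl or a longer chain on this carbonyl carbon. No supporting data accompany these numbers to account for the gap.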